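Removing Bromine from a Flavone-Linked Benzoxazine

The source may report more compounds than this note shows. Statements on the series, on what has been measured and on what is new or still open speak of the compounds shown alone.

Compound 1 `O=c1cc(-c2ccccc2)oc2cc(N3COc4c(Br)cccc4C3)ccc12`: 5.64%
Compound 2 `O=c1cc(-c2ccccc2)oc2cc(N3COc4c(Br)cc(Br)cc4C3)ccc12`: 1.64%

In a functional assay on MCF7 cells (Homo sapiens) for inhibition, read by MTT assay, with a stated time of 48 h, tested at 15 ug/mL (a higher number here means more inhibition of growth at the concentration tested, a lower number less inhibition of growth), compound 1 gives 5.64%, which is the higher of the two numbers measured, and compound 2 gives 1.64%. Among the compounds with values here, the only measured step is a number 4 percentage points lower from compound 1 to compound 2 (within the scatter), so the two numbers cannot be told apart.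

Compound 3 `O=c1cc(-c2ccccc2)oc2cc(N3COc4ccccc4C3)ccc12` has not been measured. It differs from compound 1 in one place: hydrogen in place of bromo on an aromatic carbon. This is the reverse of the kind of change seen between compound 1 and compound 2, where adding a bromine left the number within the scatter. On that basis, taking away the bromine of compound 1 is also expected to leave the result in this assay essentially unchanged, with no step beyond the scatter in either direction.

The estimate for compound 3 is therefore 6%, with a range from -5% to 17%. The expected step is a number 0.4 percentage points higher from compound 1 to compound 3 (within the scatter).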

Compound 3, percent growth inhibition at one concentration: 3.89%
For compound 3 the middle estimate is 2.1 percentage points above the measured one; low and high end bracket the measured number.
By their numbers in this assay, from the lowest: compounds 2, 3 and 1 (each within the scatter of the next).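

Until now every compound carried a bromo group on the aromatic carbon that is ortho to a fused ring, so nothing showed how the shared core behaves with hydrogen there. In this assay, the step is a number 1.8 percentage points lower from compound 1 to compound 3 (within the scatter), which means that this exchange, like the earlier addition of a second bromine, gives two numbers that cannot be told apart, and compound 3, with no bromine at all, still gives only 3.89%. No measurement is available that could explain this result.

The compounds shown leave open whether any other group on this carbon, such as an amine, a methoxy group or a carboxylic acid, would move the number beyond the usual scatter, since bromo and hydrogen are the only two compared here. They also leave open how these compounds behave at other concentrations, as each number comes from a single tested concentration and the numbers for compounds that differ in one place have so far stayed within the scatter of each other.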